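Side-chain variation at the saturated ring carbon: compound 4

The source may hold more compounds than are shown below. What is called first, only, known or untested is meant among the compounds shown, and "the series" means these compounds.

Measured so far:
compound 1 `Cn1ncc(Cl)c1-c1cc(C(=O)N[C@@H]2CN[C@H](CCNS(C)(=O)=O)C[C@H]2c2ccc(F)c(F)c2)oc1Cl`: 920 nM
compound 2 `Cn1ncc(Cl)c1-c1cc(C(=O)N[C@@H]2CN[C@H](CC(O)CO)C[C@H]2c2ccc(F)c(F)c2)oc1Cl`: 800 nM
compound 3 `Cn1ncc(Cl)c1-c1cc(C(=O)N[C@@H]2CN[C@H](CC(N)=O)C[C@H]2c2ccc(Cl)c(Cl)c2)oc1Cl`: 650 nM

In a functional assay on HCT-116 cells (Homo sapiens) for antiproliferative activity, read by sulforhodamine B assay, with a stated time of 72 h (on this read-out lower numbers stand for stronger inhibition and higher numbers for weaker inhibition), compound 3 gives the lowest of the three numbers, yet compound 2 and compound 1 both stand within the scatter of it, so no order among the three can be claimed. Compound 4 `COCC[C@@H]1C[C@@H](c2ccc(Cl)c(Cl)c2)[C@H](NC(=O)c2cc(-c3c(Cl)cnn3C)c(Cl)o2)CN1` follows from compound 3 by the change (methoxymethyl in place of carbamoyl on a saturated chain carbon bound to a saturated ring carbon). Among the compounds with values here, the only measured step that bears on this place is a 1.2-fold lower number from compound 1 to compound 2 (0.06 log units; within the scatter), and that change of side chain stayed within the scatter. On that basis the step in this assay is expected to stay within the scatter too, with no set direction. For compound 4 the expected value is 700 nM, with a range from 300 nM to 1600 nM, which corresponds to an expected step of a 1.1-fold higher number from compound 3 to compound 4 (0.03 log units; within the scatter).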

Compound 4, half-maximal inhibitory concentration: 470 nM
Compound 4: the middle estimate sits 1.5-fold (0.17 log units) above what was measured; low and high end bracket the measured number.
By their numbers in this assay, from the lowest: compounds 4, 3, 2 and 1 (each within the scatter of the next).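

In this assay the step of a 1.4-fold lower number from compound 3 to compound 4 (0.14 log units; within the scatter) gives a second side-chain exchange on a saturated chain carbon bound to a saturated ring carbon that does not leave the scatter. Methoxymethyl in place of carbamoyl removes the hydrogen-bond donor and the double bond outside aromatic rings, so neither is shown to be required at this place for the read-out. No measurement at hand accounts for this result. Going by these compounds, whether an amine or a carboxylic acid here would produce a step beyond the scatter remains open. A longer chain at this place is equally untested by the compounds shown.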